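Swapping a Cyanophenyl Arm for Pyrimidine: Rat Microsomal Stability

The compounds below may be only part of what the source reports. "The series", "measured", "known", "first", "only" and "open" are said of these compounds alone.

The measured compounds:
Compound 1, `COc1cc(OCc2cccc(-c3ccc(C#N)cc3)c2)c2cc(-c3cn4nc(OC)sc4n3)oc2c1`, gives 1.67 h in an ADME assay on microsomes from liver (Rattus norvegicus) for metabolic stability; on this read-out lower numbers stand for a shorter-lived compound and higher numbers for a longer-lived compound.
Compound 2, `COc1cc(OCc2cccc(-c3cnc(OC)nc3)c2)c2cc(-c3cn4nc(OC)sc4n3)oc2c1`, gives 1.03 h in this assay.
Compound 3, `CNC(=O)c1ccc(-c2nc(COc3cc(OC)cc4oc(-c5cn6nc(OC)sc6n5)cc34)cs2)cc1`, gives 0.517 h in this assay.

Compound 1 stands highest of the three numbers in this assay. Its nearest neighbour is compound 2, reached by the step of a 1.6-fold lower number from compound 1 to compound 2 (0.21 log units; within the scatter), which stays within the scatter. The number for compound 3 lies furthest from compound 1, and the two values show a gap beyond the scatter.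

The compound still to be measured is compound 4, `COc1cc(OCc2cccc(-c3cncnc3)c2)c2cc(-c3cn4nc(OC)sc4n3)oc2c1`. Relative to compound 1 the change is pyrimidin-5-yl in place of 4-cyanophenyl on an aromatic carbon.

For the measured compounds named here, only one measured step bears on this change: a 1.6-fold lower number from compound 1 to compound 2 (0.21 log units; within the scatter), in which a 2-methoxypyrimidin-5-yl also took the place of the 4-cyanophenyl, and the number fell without leaving the scatter. Pyrimidin-5-yl is that same ring without its methoxy, so compound 4 is expected to behave much like compound 2, with a step of a 1.7-fold lower number from compound 1 to compound 4 (0.22 log units; within the scatter) that, if anything, points downward but does not clearly exceed the scatter.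

Compound 4 is therefore estimated to give 1 h in this assay, expected to fall between 0.5 h and 2 h.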

Compound 4, half-life: 0.117 h
Estimate against measurement, compound 4: 8.5-fold (0.93 log units) above; the whole stated range lies above it.
By their numbers in this assay, from the lowest: compound 4; then compounds 3, 2 and 1 (each within the scatter of the next, the first and the last beyond it).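

In this assay, for the compounds shown here, the full change at this position turns out to be a 14-fold lower number from compound 1 to compound 4 (1.15 log units; beyond the scatter), whereas the one earlier step at the same place, a 1.6-fold lower number from compound 1 to compound 2 (0.21 log units; within the scatter), stayed within the scatter and suggested that the aromatic ring could be exchanged with little consequence. The step of an 8.8-fold lower number from compound 2 to compound 4 (0.94 log units; beyond the scatter), with hydrogen in place of methoxy on an aromatic carbon, shows that the pyrimidine ring alone does not set the number: across this pair, a single methoxy separates a value within the scatter of compound 1 from one far beyond it. Nothing shown here accounts for why the half-life falls so sharply once the methoxy is gone.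

The compounds shown leave open whether an ethoxy, a methyl or an amine on the pyrimidin-5-yl ring would keep the number close to that of compound 2, or whether methoxy is unusual in this respect. Going by these compounds alone, they also leave open whether hydrogen in place of methoxy would bring as large a fall on a different arm, such as the one carried by compound 3.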